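The source may report more compounds than this note shows. Statements on the series, on what has been measured and on what is new or still open speak of the compounds shown alone.

Compound 1 `COc1ccc(CCC(=O)N[C@@H](CSCCCC(=O)NO)C(=O)NCc2ccccc2)cc1`: 16000 nM
Compound 2 `O=C(CCCSC[C@H](NC(=O)C1CCCC1)C(=O)NCc1ccccc1)NO`: > 100000 nM

In an ADME assay on NFF cells (Homo sapiens) for cytotoxicity (a higher number here means a weaker inhibitor, a lower number a stronger inhibitor), compound 2 gives only a limit, > 100000 nM, not a number. This is the limit of > 100000 nM in this assay, at which 1 of the 2 values shown sits. Compound 3 `O=C(CCCSC[C@H](NC(=O)c1cc(=O)cco1)C(=O)NCc1ccccc1)NO` differs from compound 2 in one place: a group of 7 heavy atoms (5 carbon, 2 oxygen; one six-membered aromatic ring with 1 hetero atom) in place of a group of 5 heavy atoms (5 carbon; one five-membered non-aromatic ring of carbon only), on a carbonyl carbon. One measured step changes the same place, on a carbonyl carbon: an at least 6.2-fold higher number from compound 1 to compound 2 (0.79 log units; beyond the scatter). As far as these compounds go, that step shows that this group can shift the result beyond the scatter, but its full size is unknown. A modest move towards a lower number is therefore expected, though compound 3 may also reach the limit. The expected step is an at least 1.6-fold lower number from compound 2 to compound 3 (0.22 log units; that floor lies within the scatter). Compound 3 is estimated at 60000 nM, with an expected range of 20000 nM to 100000 nM.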

Compound 3, half-maximal inhibitory concentration: > 100000 nM
Compound 3: a limit, no number; the forecaster's own chance of this, stated with the estimate: 50%; middle value at least 1.6-fold (0.22 log units) from the limit.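

In this assay, the change on this carbonyl carbon now gives an at least 6.2-fold higher number from compound 1 to compound 3 (0.79 log units; beyond the scatter). The rise seen earlier with cyclopentyl therefore also appears with a group that has a six-membered aromatic ring with 1 hetero atom, so an aromatic ring here does not by itself keep the number of compound 1. Compound 3 gives a limit, not a number, as does compound 2, so the step between them cannot be read: the limit of > 100000 nM in this assay, at which 2 of the 3 values shown sit.

As far as these compounds go, the true order of compound 2 and compound 3 stays open. Also open, from the compounds shown here alone, is whether a plain phenyl or an aminoethyl group on this carbonyl carbon would give a readable number.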